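Aryl substituent changes on a shared core

The source may hold more compounds than are shown below. What is called first, only, known or untested is meant among the compounds shown, and "the series" means these compounds.

Measured so far, in an assay on CHO cells for displacement of a labelled ligand from adenosine receptor A1 (Homo sapiens), read by scintillation counting, with a stated time of 120 min, tested at 1 uM; a lower number here means less inhibition, a higher number more inhibition at the concentration tested (going by the name of the read-out):
compound 1 `Cc1nc2sc(-c3ccc(C(F)(F)F)cc3)nc2c(=O)[nH]1` gives 1%;
compound 2 `Cc1nc2sc(-c3ccc(C(=O)O)cc3)nc2c(=O)[nH]1` gives 1%;
compound 3 `COc1cccc(-c2nc3c(=O)[nH]c(C)nc3s2)c1` gives 1%.

Compound 3 stands level with compounds 1 and 2 in this assay; its nearest neighbour on the numbers is compound 1 and its furthest compound 2, and both gaps lie within the scatter. Compound 4 `Cc1nc2sc(-c3cccc(Cl)c3)nc2c(=O)[nH]1` differs from compound 3 by chloro in place of methoxy on an aromatic carbon. Going by the values given here, the only measured step at the aryl group, no change at the digits printed from compound 1 to compound 2 (within the scatter), was flat, and no step exchanges methoxy for chloro, so the expected change, a number 1 percentage points higher from compound 3 to compound 4 (within the scatter), is none beyond the scatter. Compound 4 is thus estimated at 2%, with a range from 0% to 12%.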

Compound 4, a percentage reported as inhibition, at one concentration (the size of the read-out at that concentration, not a potency): 24%
Estimate against measurement, compound 4: 22 percentage points below; measured number above the stated range.
By their numbers in this assay, from the lowest: compounds 1, 2 and 3 (each within the scatter of the next); then compound 4.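

In this assay the aryl substituent can move the read-out: chloro in place of methoxy gives a number 23 percentage points higher from compound 3 to compound 4 (beyond the scatter) and is the only step shown that lies beyond the scatter. The flat step between compound 1 and compound 2 did not reveal this sensitivity, and it appears here on an aromatic carbon meta to a large group. No measurement shown accounts for the rise.

Going by these compounds, whether it comes from gaining chloro or losing methoxy remains open. Also open, on these data alone, is how bromo or an amine at the same place would read.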